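The source may report more compounds than this note shows. Statements on the series, on what has been measured and on what is new or still open speak of the compounds shown alone.

Compound 2 `COc1ccc2nc(C)cc(OCC(=O)Nc3cc(F)cc(F)c3)c2c1` belongs to a small set built on one shared core. In a toxicity assay on HepG2 cells (Homo sapiens) for inhibition, read by CellTiter-Glo, with a stated time of 48 h (on this read-out lower numbers stand for stronger inhibition and higher numbers for weaker inhibition), compound 2 reaches only a limit, > 100000 nM. Compound 1 `COc1ccc2nc(C)cc(OCC(=O)Nc3c(C)cccc3C)c2c1` differs from compound 2 only in the group on the amide-type nitrogen, 2,6-dimethylphenyl in place of 3,5-difluorophenyl. In this assay compound 1 likewise reaches only a limit, > 100000 nM. The step that the two limits leave unreadable from compound 1 to compound 2 therefore cannot be read, and where compound 2 stands on the numbers shown is simply at the limit of > 100000 nM in this assay, at which 2 of the 2 values shown sit.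

Compound 3 `COc1ccc2nc(C)cc(OCC(=O)Nc3ccc(Cl)cc3Cl)c2c1` has not yet been measured in this assay. It differs from compound 2 by 2,4-dichlorophenyl in place of 3,5-difluorophenyl on an amide-type nitrogen. For the measured compounds named here, the only measured step that touches this position is the one between compound 1 and compound 2, and its size is not readable. The expected step that the limit leaves unreadable from compound 2 to compound 3 therefore rests on no measured size or direction, and compound 3 is expected to remain at the limit as well. The estimate for compound 3 in this assay is 150000 nM, with a range from 60000 nM to 400000 nM.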

Compound 3, half-maximal inhibitory concentration: > 100000 nM
Compound 3 ended at the assay's limit; the forecaster's own chance of this, stated with the estimate: 80%; the middle value does not contradict the limit.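

In this assay, no new step can be read among compound 1, compound 2 and compound 3, as all three sit at one limit of the assay: the limit of > 100000 nM in this assay, at which 3 of the 3 values shown sit. The compounds shown leave open whether any group on the amide-type nitrogen, or any change elsewhere on the shared core, would give a readable value.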